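Swapping the Carbonyl Link for a Sulfonyl Link

The source may report more compounds than this note shows. Statements on the series, on what has been measured and on what is new or still open speak of the compounds shown alone.

Compound 1 `O=C(/C=C/c1cccc(NC(=O)c2ccccc2Cl)c1)c1nc2ccccc2[nH]1`: 3690 nM
Compound 2 `O=C(Nc1cccc(/C=C/C(=O)c2nc3ccccc3[nH]2)c1)c1cccc(Cl)c1`: 3370 nM
Compound 3 `O=C(Nc1cccc(/C=C/C(=O)c2nc3ccccc3[nH]2)c1)c1cc(Cl)cc(Cl)c1`: 3660 nM

In a functional assay on 143B cells (Homo sapiens) for antiproliferative activity, read by MTT assay, with a stated time of 48 h (on this read-out higher numbers stand for weaker inhibition and lower numbers for stronger inhibition), compound 2 gives the lowest of the three numbers, yet the step of a 1.1-fold lower number from compound 1 to compound 2 (0.04 log units; within the scatter) and the step of a 1.1-fold higher number from compound 2 to compound 3 (0.04 log units; within the scatter) both lie within the scatter, so the three compounds cannot be told apart. Compound 4 `O=C(/C=C/c1cccc(NS(=O)(=O)c2cccc(Cl)c2)c1)c1nc2ccccc2[nH]1` differs from compound 2 in one place: (3-chlorophenyl)sulfonyl in place of (3-chlorophenyl)carbonyl on a nitrogen on an aromatic ring. Within the data shown here, every measured step only exchanges one chlorine-bearing phenyl for another on the carbonyl carbon; none touches the link itself, so no measured step bears on this change. With nothing pointing either way, the expected step for compound 4 is a 1.0-fold higher number from compound 2 to compound 4 (0.00 log units; within the scatter), none beyond the scatter. Compound 4 is therefore estimated at 3400 nM, with a range from 1400 nM to 8500 nM.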

Compound 4, half-maximal inhibitory concentration: 2510 nM
Beside the measured number, compound 4's estimate is 1.4-fold (0.13 log units) above it; the range from low to high includes it.
By their numbers in this assay, from the lowest: compounds 4, 2, 3 and 1 (each within the scatter of the next).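

Until this point only the chlorine-bearing phenyl had varied, while compound 4 changes the link itself, and in this assay a 1.3-fold lower number from compound 2 to compound 4 (0.13 log units; within the scatter) shows that carbonyl and sulfonyl links on this nitrogen cannot be told apart. The other two comparisons agree, with a 1.5-fold lower number from compound 3 to compound 4 (0.16 log units; within the scatter) and a 1.5-fold lower number from compound 1 to compound 4 (0.17 log units; within the scatter), although each of these also changes the chlorine pattern. No measurement here accounts for this result.

Still open, from the compounds shown here alone, is whether a different link, such as a urea or a methylene group, would give a number beyond the scatter. Also open, going by these compounds, is how the sulfonyl series responds when an amine or a carboxylic acid replaces the chlorine on its phenyl ring.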